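This account rests on a few compounds, and the source may have more. Where it says the series, first, only, none or still open, it means among the compounds named here.

Compound 1, `CC(=O)N[C@@H](CSC(=O)Nc1ccc(Br)cc1)C(=O)O`: > 200000 nM
Compound 2, `CC(=O)N[C@@H](CSC(=O)Nc1ccc(F)cc1)C(=O)O`: > 200000 nM
Compound 3, `CC(=O)N[C@@H](CSC(=O)Nc1ccc(I)cc1)C(=O)O`: > 200000 nM

In a functional assay on OVCAR-3 cells (Homo sapiens) for cytotoxicity, read by MTT assay, with a stated time of 6 days (a higher number here means a weaker inhibitor, a lower number a stronger inhibitor), compound 3 sits at the limit of > 200000 nM in this assay, at which 3 of the 3 values shown sit, which is a limit of the assay and not a number. Compound 1 reaches the same limit in this assay. Compound 2 likewise reaches that limit. Because all three values are limits, the steps a step that the two limits leave unreadable from compound 1 to compound 2, a step that the two limits leave unreadable from compound 1 to compound 3 and a step that the two limits leave unreadable from compound 2 to compound 3 cannot be read in size or direction; they show only that none of the three halogens at this position brings the compound within the measurable range.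

Compound 4, `CC(=O)N[C@@H](CSC(=O)Nc1ccc(Cl)cc1)C(=O)O`, differs from compound 3 by chloro in place of iodo on an aromatic carbon. All three measured steps bear on this change, since each swaps one halogen for another at the same aromatic carbon, and each leaves the value at the limit. Compound 4 is therefore expected to remain at the limit as well, with an estimated value of 250000 nM and a range from 100000 nM to 1000000 nM. The step that the limit leaves unreadable from compound 3 to compound 4 is expected to be none beyond the scatter.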

Compound 4, half-maximal inhibitory concentration: > 200000 nM
Compound 4 was reported as a limit (the forecaster's own chance of this, stated with the estimate: 90%); the middle value lies beyond the limit too.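

In this assay compound 4 gives > 200000 nM, which is a limit of the assay and not a number. Its steps to compound 1, compound 2 and compound 3 cannot be read. The compounds shown leave open how far any of the four lies beyond this limit.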